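Exchanging the Ring Methyl for 4-Bromophenyl

A few compounds are considered here, and "the series" means these few. Any claim that something is new, unique, unknown or untested is made for them only; others in the source may bear on it.

Three ureas built on one shared core have been measured in an assay on isolated protein for inhibition of Ephrin type-A receptor 2 (Homo sapiens), read by thermal shift assay, tested at 10 uM; a higher number here means that the compound stabilises the target more against heat, a lower number that the compound stabilises the target less. Compound 1 `CC(C)(C)c1cc(NC(=O)Nc2cc(F)cc(F)c2)n(-c2ccccc2)n1` gives 2.7 degrees C. Compound 2 `Cc1ccc(-n2nc(C(C)(C)C)cc2NC(=O)Nc2cc(F)cc(F)c2)cc1` gives 1.9 degrees C. Compound 3 `Cn1nc(C(C)(C)C)cc1NC(=O)Nc1cc(F)cc(F)c1` gives 0.4 degrees C, the lowest of the three; its distance to each of the other two lies beyond the scatter.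

Compound 4 `CC(C)(C)c1cc(NC(=O)Nc2cc(F)cc(F)c2)n(-c2ccc(Br)cc2)n1` has not yet been measured. It differs from compound 3 in a single place: 4-bromophenyl in place of methyl on an aromatic nitrogen.

For the measured compounds named here, two measured steps bear directly on this change. Each of them also swaps a six-membered carbon ring on that nitrogen for a methyl. The step of a number 2.3 degrees C lower from compound 1 to compound 3 (beyond the scatter) and the step of a number 1.5 degrees C lower from compound 2 to compound 3 (beyond the scatter) both leave the methyl compound modestly below its ring-bearing partner. Read in the opposite direction, restoring a ring in place of the methyl raises the reading by a modest amount. The further step a number 0.80 degrees C lower from compound 1 to compound 2 (within the scatter) shows that adding a small group on a ring carbon left the reading within the scatter. Since the entering group is again a six-membered carbon ring, this time carrying bromine, a modest rise is expected: a number 1.8 degrees C higher from compound 3 to compound 4 (beyond the scatter). For compound 4 the estimated value is 2.2 degrees C, with a range from 1 degrees C to 3.4 degrees C.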

Compound 4, shift of the target's melting temperature: 1.3 degrees C
Compound 4: the middle estimate sits 0.90 degrees C above what was measured; low and high end bracket the measured number.
By their numbers in this assay, from the lowest: compounds 3, 4, 2 and 1 (each within the scatter of the next, the first and the last beyond it).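

In this assay, 4-bromophenyl on the aromatic nitrogen gives a number 0.90 degrees C higher from compound 3 to compound 4 (within the scatter), so a six-membered carbon ring at this place does not always stand clear of methyl, as the phenyl of compound 1 and the 4-methylphenyl of compound 2 did. What the ring carries can also matter: bromo in place of hydrogen gives a number 1.4 degrees C lower from compound 1 to compound 4 (beyond the scatter), a step that reaches beyond the scatter, whereas methyl in place of hydrogen gave a number 0.80 degrees C lower from compound 1 to compound 2 (within the scatter). Yet bromo in place of methyl gives a number 0.60 degrees C lower from compound 2 to compound 4 (within the scatter), so these two ring-substituted compounds cannot be told apart directly, and they differ only in how each stands against the unsubstituted phenyl of compound 1.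

Nothing shown here gives a reason for these readings. On these data alone, whether a methoxy group, an amine or a carboxylic acid in place of the bromo would lift the reading clear of compound 3 stays open, as does what a longer chain would do in place of the methyl of compound 3.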